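Swapping One Methyl for Hydrogen

The source may report more compounds than this note shows. Statements on the series, on what has been measured and on what is new or still open speak of the compounds shown alone.

Compound 1 `CC1(COc2ccc(OC(F)(F)F)cc2)Cn2cc([N+](=O)[O-])nc2O1`, compound 2 `CC1(COc2ccc(-c3ccc(F)cc3)cc2)Cn2cc([N+](=O)[O-])nc2O1` and compound 3 `CC1(COc2ccc(C(F)(F)F)cc2)Cn2cc([N+](=O)[O-])nc2O1` share one core and differ in a group on an aromatic carbon. In an ADME assay on MRC5 cells (Homo sapiens) for cytotoxicity, read by fluorescence, with a stated time of 72 h (a lower number here means a stronger inhibitor, a higher number a weaker inhibitor), compound 1 gives > 64000 nM, which is a limit and not a number. Compound 2 gives > 64000 nM, also a limit. Compound 3 gives > 64000 nM, again a limit. All three therefore stand at one place: the limit of > 64000 nM in this assay, at which 3 of the 3 values shown sit. The measured steps are a step that the two limits leave unreadable from compound 1 to compound 2, a step that the two limits leave unreadable from compound 1 to compound 3 and a step that the two limits leave unreadable from compound 2 to compound 3, so none offers a usable size, and each concerns the aromatic carbon rather than the site changed next.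

Compound 4 `O=[N+]([O-])c1cn2c(n1)OC(COc1ccc(-c3ccc(F)cc3)cc1)C2` departs from compound 2 by hydrogen in place of methyl on a saturated ring carbon. Among the measured compounds shown here, the only guide is compound 2 with > 64000 nM, a limit, so no step beyond the scatter is expected in this assay. The estimated change is a number no higher from compound 2 to compound 4 (the limit leaves the size open). For compound 4 the expected value is 64000 nM, with an estimated range from 30000 nM to 128000 nM.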

Compound 4, half-maximal inhibitory concentration: > 64000 nM
Compound 4: only a limit was reported; the forecaster's own chance of this, stated with the estimate: 80%; the middle value sits exactly at the limit.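

In this assay compound 4 gives > 64000 nM, which is a limit and not a number. Compound 2 also stands at a limit, so no step can be read between compound 2 and compound 4. The compounds shown leave open whether hydrogen in place of methyl on a saturated ring carbon changes the true value at all, and by how much.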